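Aryl swap on the triazole of a weak sulfonamide series

The source may hold more compounds than are shown below. What is called first, only, known or untested is meant among the compounds shown, and "the series" means these compounds.

Compound 1 `O=c1[nH]cc(S(=O)(=O)Nc2ccc(-c3cn(-c4ccccc4)nn3)cc2)c(=O)[nH]1` gives 18000 nM in a functional assay on OVCAR-3 cells (Homo sapiens) for antiproliferative activity, read by MTT assay, with a stated time of 24 h; a lower number here means a stronger inhibitor, a higher number a weaker inhibitor. Compound 2 `O=c1[nH]cc(S(=O)(=O)Nc2ccc(-c3cn(-c4ccc(F)cc4)nn3)cc2)c(=O)[nH]1` reaches only a limit of the assay, > 20000 nM, and so carries no exact number. Compound 2 thus sits at the limit of > 20000 nM in this assay, at which 1 of the 2 values shown sits. Within the data shown here, the only measured step, an at least 1.1-fold higher number from compound 1 to compound 2 (0.04 log units; that floor lies within the scatter), does not separate the two compounds in this assay. Compound 3 `O=c1[nH]cc(S(=O)(=O)Nc2ccc(-c3cn(-c4ccccc4Cl)nn3)cc2)c(=O)[nH]1` carries the change (2-chlorophenyl in place of 4-fluorophenyl on an aromatic nitrogen). Among the measured compounds shown here, no measured step matches a move of a halogen to another position of the phenyl ring; the one recorded step, from hydrogen to fluoro, stayed within the scatter, so the data give no ground to expect a step in this assay beyond the scatter in either direction. With compound 2 standing at a limit, compound 3 is expected to land near that same limit, estimated at 22000 nM with a range from 9000 nM to 60000 nM. The step that the limit leaves unreadable from compound 2 to compound 3 is accordingly expected to be small.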

Compound 3, half-maximal inhibitory concentration: 4270 nM
Estimate against measurement, compound 3: 5.2-fold (0.71 log units) above, and the stated range ends above it.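

In this assay the aryl group on the aromatic nitrogen now moves the read-out beyond the scatter: 2-chlorophenyl in place of 4-fluorophenyl gives an at least 4.6-fold lower number from compound 2 to compound 3 (0.67 log units; beyond the scatter) and chloro in place of hydrogen gives a 4.2-fold lower number from compound 1 to compound 3 (0.62 log units; beyond the scatter) on the same core. The first of these steps is only a floor because compound 2 stands at a limit of the assay: the limit of > 20000 nM in this assay, at which 1 of the 3 values shown sits. The position therefore responds to its aryl substituent, which an at least 1.1-fold higher number from compound 1 to compound 2 (0.04 log units; that floor lies within the scatter) could not show.

The compounds shown do not separate the identity of the halogen from its place on the phenyl ring, a question that 2-fluorophenyl and 4-chlorophenyl would address. Going by these compounds, how this position responds to a group other than a halogen, such as methoxy or an amine on the phenyl ring, also stays open.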